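The source may hold more compounds than are shown below. What is called first, only, known or untested is meant among the compounds shown, and "the series" means these compounds.

Of the compounds shown here, three have so far been measured in an assay on CHO-K1 cells for displacement of a labelled ligand from adenosine receptor A1 (Homo sapiens), tested at 50 uM; on this read-out higher numbers stand for more inhibition at the one concentration tested (going by the name of the read-out) and lower numbers for less inhibition. Compound 1 `CCOC(=O)c1nn(-c2cccc(Cl)c2)c(=O)c2c(N)scc12` gives 100%. Compound 2 `CCOC(=O)c1nn(-c2cccc(C(F)(F)F)c2)c(=O)c2c(N)scc12` gives 32%. Compound 3 `CCOC(=O)c1nn(-c2ccc(O)cc2)c(=O)c2c(N)scc12` gives 65.8%. On these numbers compound 3 stands second highest of the three, with compound 1 above it and compound 2 below it, each gap lying beyond the scatter.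

Two measured steps are known. Trifluoromethyl in place of chloro on an aromatic carbon gave a number 68 percentage points lower from compound 1 to compound 2 (beyond the scatter). 4-hydroxyphenyl in place of 3-chlorophenyl on an aromatic nitrogen gave a number 34.2 percentage points lower from compound 1 to compound 3 (beyond the scatter).

Compound 4 `CCOC(=O)c1nn(-c2ccc(OC(C)=O)cc2)c(=O)c2c(N)scc12` has not yet been measured in this assay. It differs from compound 3 in one place: acetyl in place of hydrogen on an oxygen on an aromatic ring. Neither measured step touches the hydroxy group itself; both altered the ring attached to the aromatic nitrogen, and both were large, showing that changes in this part of the shared core can shift the read-out well beyond the scatter. Among the compounds with values here, no measured step tells the direction of a change from hydroxy to acetoxy. A moderate downward step is therefore expected, a number 10.8 percentage points lower from compound 3 to compound 4 (beyond the scatter), with a wide range to reflect the uncertainty. Compound 4 is expected to give about 55%, between 25% and 85%.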

Compound 4, a percentage reported as inhibition, at one concentration (the size of the read-out at that concentration, not a potency): 48.9%
Beside the measured number, compound 4's estimate is 6.1 percentage points above it; the measured number falls inside the stated range.
By their numbers in this assay, from the lowest: compound 2; then compound 4; then compound 3; then compound 1.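

In this assay, within the data shown here, the change from hydroxy to acetoxy gives a number 16.9 percentage points lower from compound 3 to compound 4 (beyond the scatter), and this is the first step that alters the oxygen on the aromatic ring rather than replacing a group or the whole ring. The drop lies beyond the scatter but is modest, unlike the two large earlier steps, and compound 4 still gives 48.9% at the one concentration tested, so in this series the hydrogen of the hydroxy group is not required for a sizeable read-out. Nothing available explains why the number falls when acetyl takes the place of that hydrogen.

From the compounds shown here alone, it remains open whether the drop follows from losing the hydrogen or from adding the acetyl group, and a methoxy group on the same oxygen would help separate those two readings. Going by these compounds, how a longer chain such as butanoyl on that oxygen, or an amine in place of the hydroxy group, would read also remains open.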